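The source may hold more compounds than are shown below. What is called first, only, known or untested is meant among the compounds shown, and "the series" means these compounds.

Measured so far in an assay on isolated protein for inhibition of Amine oxidase [flavin-containing] A (Homo sapiens), read by fluorescence, with a stated time of 15 min; a lower number here means a stronger inhibitor, a higher number a weaker inhibitor:
- compound 1 `COc1ccc(/C=C/c2cc(OC)cc(OC)c2/C=C/C(=O)c2cc3ccc(Br)cc3oc2=O)cc1`: 3010 nM
- compound 2 `COc1ccc(/C=C/c2cc(OC)cc(OC)c2/C=C/C(=O)c2cc3cccc(C)c3oc2=O)cc1`: > 60000 nM
- compound 3 `COc1ccc(/C=C/c2cc(OC)cc(OC)c2/C=C/C(=O)c2cc3ccc(C)cc3oc2=O)cc1`: 58200 nM

The value of compound 2 is a limit of this assay, not a number (the limit of > 60000 nM in this assay, at which 1 of the 3 values shown sits). Compound 3 sits highest of the two numbers given; its nearest neighbour is compound 1, separated by a 19-fold higher number from compound 1 to compound 3 (1.29 log units; beyond the scatter), a change of methyl in place of bromo on an aromatic carbon. Compound 2 and compound 3 differ by an at least 1.0-fold lower number from compound 2 to compound 3 (0.01 log units; that floor lies within the scatter), which lies within the scatter.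

Compound 4 `COc1ccc(/C=C/c2cc(OC)cc(OC)c2/C=C/C(=O)c2cc3cc(Cl)ccc3oc2=O)cc1` is not yet measured. Against compound 3 it shows (a group of 12 heavy atoms (9 carbon, 2 oxygen, 1 chlorine; one six-membered aromatic ring of carbon only, one six-membered aromatic ring with 1 hetero atom) in place of a group of 12 heavy atoms (10 carbon, 2 oxygen; one six-membered aromatic ring of carbon only, one six-membered aromatic ring with 1 hetero atom), on a carbonyl carbon). Within the data shown here, the only measured step that bears on a halogen-for-methyl exchange is the one from compound 1 to compound 3, which was large and went upward; read in the other direction it points to a lower number when a halogen enters. The chlorine in compound 4 is, however, not arranged as the bromine in compound 1, so a smaller step is expected, a 6.5-fold lower number from compound 3 to compound 4 (0.81 log units; beyond the scatter). Compound 4 is estimated at 9000 nM, between 2500 nM and 35000 nM.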

Compound 4, half-maximal inhibitory concentration: > 60000 nM
Compound 4: a limit, no number; the forecaster's own chance of this, stated with the estimate: 10%; middle value at least 6.6-fold (0.82 log units) from the limit.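

In this assay compound 4 gives > 60000 nM, a limit of the assay and not a number. A halogen on this group therefore does not by itself give a lower number: chlorine in place of methyl gives an at least 1.0-fold higher number from compound 3 to compound 4 (0.01 log units; that floor lies within the scatter), whereas the bromine compound stays clearly apart, with an at least 19-fold higher number from compound 1 to compound 4 (1.29 log units; beyond the scatter). The step between compound 2 and compound 4 cannot be read, since both values are limits: the limit of > 60000 nM in this assay, at which 2 of the 4 values shown sit.

The step between the bromine and chlorine compounds changes both the halogen and its arrangement on the group, so the compounds shown do not separate these two changes. Going by these compounds, whether fluoro or an amine on this group, attached to the same carbonyl carbon, would give a number in this assay remains open.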